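Two Inactive Cyclohexanone Dienones and a Phenol Analogue

This account rests on a few compounds, and the source may have more. Where it says the series, first, only, none or still open, it means among the compounds named here.

Compound 1 `COc1ccccc1/C=C1\CCC/C(=C\c2cccc(OC)c2OC)C1=O` is a symmetric-looking dienone with a methoxy group on each aromatic ring. In a functional assay on SW-620 cells (Homo sapiens) for cytotoxicity, read by MTT assay, with a stated time of 72 h (a lower number here means a stronger inhibitor, a higher number a weaker inhibitor), compound 1 gives only the limit > 20000 nM, not a number. Compound 2 `COc1ccc(/C=C2\CCC/C(=C\c3cccc(OC)c3OC)C2=O)c(OC)c1` adds a methoxy group to one ring. In this assay compound 2 also gives only the limit > 20000 nM. For the measured compounds named here, the step from one to the other, a step that the two limits leave unreadable from compound 1 to compound 2, therefore cannot be read, and the only evidence is that (the limit of > 20000 nM in this assay, at which 2 of the 2 values shown sit).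

Compound 3 `COc1cccc(/C=C2\CCC/C(=C\c3ccc(O)c(Cl)c3)C2=O)c1OC` differs from compound 1 by 3-chloro-4-hydroxyphenyl in place of 2-methoxyphenyl on a double-bonded chain carbon bound to a double-bonded ring carbon. Going by the values given here, no measured step shows how a hydroxy or chlorine group on this ring changes potency, so the change expected from compound 1 to compound 3 is uncertain, with an at least 1.3-fold lower number from compound 1 to compound 3 (0.12 log units; that floor lies within the scatter) as the estimate. Compound 3 is expected to sit near 15000 nM, between 3000 nM and 60000 nM.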

Compound 3, half-maximal inhibitory concentration: 16800 nM
Compound 3: the middle estimate sits 1.1-fold (0.05 log units) below what was measured; the measured number falls inside the stated range.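

For the compounds shown here, this position can give a readable number: in this assay compound 3 gives 16800 nM, the first value in this set that is not a limit. Placing 3-chloro-4-hydroxyphenyl in place of 2-methoxyphenyl on a double-bonded chain carbon bound to a double-bonded ring carbon gives an at least 1.1-fold lower number from compound 1 to compound 3 (0.07 log units; that floor lies within the scatter), so the change cannot be shown to exceed ordinary assay variation. The comparison remains one-sided, with only a floor for its size, and the other values shown are still limits: the limit of > 20000 nM in this assay, at which 2 of the 3 values shown sit.

The hydroxy and chlorine groups enter together, which leaves open what either does alone. Also open, going by these compounds, is how an amine or a carboxylic acid in place of the 3-chloro-4-hydroxyphenyl would read in this assay.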